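Methylamino for methyl on a furan-bearing nucleoside

A few compounds are considered here, and "the series" means these few. Any claim that something is new, unique, unknown or untested is made for them only; others in the source may bear on it.

Compound 1 `C#Cc1cn([C@@H]2O[C@H](CO)[C@@H](O)[C@H]2O)c2ncnc(C)c12` carries an ethynyl group and gives 160 nM in a functional assay on CEM-DNR-bulk cells (Homo sapiens), read by MTT assay, with a stated time of 72 h; a lower number here means a stronger inhibitor, a higher number a weaker inhibitor. Compound 2 `Cc1ncnc2c1c(-c1cc3ccccc3o1)cn2[C@@H]1O[C@H](CO)[C@@H](O)[C@H]1O` carries 1-benzofuran-2-yl and reaches only the limit of the assay, > 20000 nM. Compound 3 `Cc1ncnc2c1c(-c1ccoc1)cn2[C@@H]1O[C@H](CO)[C@@H](O)[C@H]1O` carries furan-3-yl and likewise reaches only the limit of the assay, > 20000 nM. Both changes from the ethynyl compound are large: an at least 120-fold higher number from compound 1 to compound 2 (2.09 log units; beyond the scatter) and an at least 120-fold higher number from compound 1 to compound 3 (2.09 log units; beyond the scatter). Between compound 2 and compound 3 the step cannot be read, a step that the two limits leave unreadable from compound 2 to compound 3, because of the limit of > 20000 nM in this assay, at which 2 of the 3 values shown sit. Compound 3 thus stands at that limit with no number of its own.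

Compound 4 `CNc1ncnc2c1c(-c1ccoc1)cn2[C@@H]1O[C@H](CO)[C@@H](O)[C@H]1O` differs from compound 3 in one place: methylamino in place of methyl on an aromatic carbon. Among the measured compounds shown here, no measured step touches this methyl group, so the two large steps above cannot guide the size of this change, and the starting point itself is only a limit. The estimate for compound 4 is therefore 15000 nM, within 2000 nM to 40000 nM, an expected step of an at least 1.3-fold lower number from compound 3 to compound 4 (0.12 log units; that floor lies within the scatter), with a real chance that only a limit is reported again.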

Compound 4, half-maximal inhibitory concentration: > 20000 nM
Compound 4: only a limit was reported (the forecaster's own chance of this, stated with the estimate: 60%); middle value at least 1.3-fold (0.12 log units) from the limit.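

Compound 3 and compound 4 both stop at a limit rather than a number in this assay, so the step between them cannot be read: the limit of > 20000 nM in this assay, at which 3 of the 4 values shown sit. The compounds shown leave open whether methylamino in place of methyl changes the activity at all.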